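Amide Substituent Changes and Cytotoxicity in Colon Cancer Cells

The source may hold more compounds than are shown below. What is called first, only, known or untested is meant among the compounds shown, and "the series" means these compounds.

Measured so far:
compound 1 `CC1=C(C(C)C(=O)N(C)CCN(C)C)c2cc(F)ccc2/C1=C\c1ccc([S+](C)[O-])cc1`: 11900 nM
compound 2 `CC1=C(C(C)C(=O)N(CCNC(C)C)C(C)C)c2cc(F)ccc2/C1=C\c1ccc([S+](C)[O-])cc1`: 8060 nM
compound 3 `CC1=C(C(C)C(=O)NCCN2CCNCC2)c2cc(F)ccc2/C1=C\c1ccc([S+](C)[O-])cc1`: > 50000 nM (a limit of the assay, not a number)

The three compounds share one core and differ only in the group on the carbonyl carbon. In a functional assay on HT-29 cells (Homo sapiens) for inhibition, read by CellTiter-Glo, with a stated time of 72 h (on this read-out lower numbers stand for higher toxicity in this test and higher numbers for lower toxicity in this test), compound 1 gives 11900 nM and compound 2 gives 8060 nM; the step of a 1.5-fold lower number from compound 1 to compound 2 (0.17 log units; within the scatter) is within the scatter. From the compounds shown here alone, compound 3 reaches only the limit of this assay, > 50000 nM, so its true number is unknown (the limit of > 50000 nM in this assay, at which 1 of the 3 values shown sits). The steps of an at least 4.2-fold higher number from compound 1 to compound 3 (0.62 log units; beyond the scatter) and an at least 6.2-fold higher number from compound 2 to compound 3 (0.79 log units; beyond the scatter) both run toward higher numbers, so compound 3 stands at the least toxic end of what has been measured, and only a bound is known because of the limit of > 50000 nM in this assay, at which 1 of the 3 values shown sits.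

Compound 4 `CC1=C(C(C)C(=O)N2CCN(CCN(C)C)CC2)c2cc(F)ccc2/C1=C\c1ccc([S+](C)[O-])cc1` has not been measured. Its change from compound 3 is 4-(2-(dimethylamino)ethyl)piperazin-1-yl in place of (2-(piperazin-1-yl)ethyl)amino on a carbonyl carbon. Like compound 1 and compound 2, compound 4 carries a group with no hydrogen-bond donors on the carbonyl carbon, and those two compounds gave numbers rather than a limit. The step from compound 3 to compound 4 is therefore expected to be an at least 3.3-fold lower number from compound 3 to compound 4 (0.52 log units; beyond the scatter), back toward more toxicity, though the bare limit for compound 3 makes its size uncertain. Compound 4 is estimated at 15000 nM, with a range of 6000 nM to 50000 nM.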

Compound 4, half-maximal cytotoxic concentration: 38400 nM
Compound 4: middle estimate off by 2.6-fold (0.41 log units), on the low side; measured number inside the range.
By their numbers in this assay, from the lowest: compounds 2 and 1 (each within the scatter of the next); then compound 4. At a limit, above all of these: compound 3.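

On the carbonyl carbon, 4-(2-(dimethylamino)ethyl)piperazin-1-yl gives a measured number higher than those of the open-chain amides in this assay, with a 3.2-fold higher number from compound 1 to compound 4 (0.51 log units; beyond the scatter) and a 4.8-fold higher number from compound 2 to compound 4 (0.68 log units; beyond the scatter). The entering group has a six-membered non-aromatic ring with 2 hetero atoms and 0 hydrogen-bond donors, so among these compounds a ring-bearing group can sit toward lower toxicity without any donors. The remaining step is an at least 1.3-fold lower number from compound 3 to compound 4 (0.11 log units; that floor lies within the scatter), and its true size is unknown: the limit of > 50000 nM in this assay, at which 1 of the 4 values shown sits.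

From the compounds shown here alone, what stays open is whether the ring or the dimethylamino-ended chain on it goes with the higher number. A morpholine or a plain piperidine on the carbonyl carbon would help to separate the two.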